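Amide nitrogen substituent and lipophilicity: compound 2 to compound 4

This account rests on a few compounds, and the source may have more. Where it says the series, first, only, none or still open, it means among the compounds named here.

Measured so far in a physicochemical assay for lipophilicity, at pH 7.4; on this read-out lower numbers stand for lower lipophilicity and higher numbers for higher lipophilicity:
compound 1 `CNC(=O)c1cc(C(=O)NC2CC2)cn(Cc2cccc(F)c2)c1=O`: 3.2
compound 2 `CNC(=O)c1cc(C(=O)NC)c(=O)n(Cc2ccccc2)c1`: 2.4
compound 3 `CNC(=O)c1ccc(=O)n(Cc2ccccc2)c1`: 1.6

Compound 2 stands second highest of the three numbers. Its nearest neighbour is compound 3, the step being a number 0.80 log units lower from compound 2 to compound 3 (beyond the scatter); compound 1 sits furthest from it and higher. For the measured compounds named here, compound 1 and compound 2 differ in two places, so no single step joins them and only their two values can be set side by side.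

The change to compound 4 `CNC(=O)c1cc(C(=O)NC2CCC2)cn(Cc2ccccc2)c1=O` is cyclobutyl in place of methyl on an amide-type nitrogen. Going by the values given here, no measured step makes this exact change. Among the compounds with values here, the one measured step, a number 0.80 log units lower from compound 2 to compound 3 (beyond the scatter), removes a methylcarbamoyl from an aromatic carbon and shows that this assay answers to changes on this core by more than the scatter. Compound 1, which among its two differences from compound 2 carries a larger group on the same amide nitrogen, reads higher than compound 2, and that direction is taken as the pointer here.

Four carbons enter in a four-membered non-aromatic ring where one methyl carbon leaves, with donors and acceptors unchanged; the expected step from compound 2 to compound 4 is a number 1.00 log units higher from compound 2 to compound 4 (beyond the scatter), upward and beyond the scatter. Compound 4 is therefore estimated at 3.4, with a range from 2.9 to 3.9.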

Compound 4, distribution coefficient: 3.8
Beside the measured number, compound 4's estimate is 0.40 log units below it; the measured number falls inside the stated range.
By their numbers in this assay, from the lowest: compound 3; then compound 2; then compound 1; then compound 4.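

In this assay, for the compounds shown here, the result gives the first single-place reading at this amide-type nitrogen: a number 1.40 log units higher from compound 2 to compound 4 (beyond the scatter) is printed as large, whereas a number 0.80 log units lower from compound 2 to compound 3 (beyond the scatter) is printed as modest and belongs to a different change, on an aromatic carbon. The read-out on this core therefore responds strongly to replacing methyl with cyclobutyl, a change that adds one four-membered non-aromatic ring of carbon only while both groups carry no hydrogen-bond donors, no hydrogen-bond acceptors and no net charge. No measurement is available that accounts for the size of this step.

A single pair cannot show whether the rise tracks the carbon count or the presence of the ring, and an open n-butyl chain on the same nitrogen would separate those two readings. Also open, as far as these compounds go, is whether a cyclobutyl carrying a hydroxyl or an amine would keep the number near that of compound 4 3.8 or bring it back towards that of compound 2 2.4 in this assay.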